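This account rests on a few compounds, and the source may have more. Where it says the series, first, only, none or still open, it means among the compounds named here.

Three related compounds have been measured so far, and their numbers spread very widely. In a functional assay on cells (Neutrophil, Homo sapiens) for inhibition, with a stated time of 10 min (a higher number here means a weaker inhibitor, a lower number a stronger inhibitor), compound 1 `CCCC(O)Cn1ncc(C(=O)OCC)c1NC(=O)NC(C)C` gives 1 nM while compound 2 `CCOC(=O)c1cnn(CC(O)CC)c1NC(=O)Nc1cccc2ccccc12` gives 9.6 nM and compound 3 `CCOC(=O)c1cnn(CC(O)CC)c1NC(=O)Nc1ccccc1F` gives 0.0016 nM as the lowest of the three numbers. Compound 3 is therefore the strongest inhibitor of the group, and both of the others lie beyond the usual scatter from it.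

The next compound is compound 4 `CCOC(=O)c1cnn(CC(O)CC)c1NC(=O)Nc1cccc(F)c1`, which has the same atoms as compound 3 joined differently. The change is 3-fluorophenyl in place of 2-fluorophenyl on an amide-type nitrogen, and nothing else differs. For the measured compounds named here, no measured pair shows a change of this kind, so the data give no direct guide to its size.

Compound 3 sits so low at 0.0016 nM that a change to it seems more likely to raise the number than to lower it, and the value of compound 1 at 1 nM offers a more ordinary level to drift toward. The expected change is a 63-fold higher number from compound 3 to compound 4 (1.80 log units; beyond the scatter) toward a weaker inhibitor, probably beyond the scatter. Compound 4 is expected near 0.1 nM with an estimated range from 0.004 nM to 3 nM as a rough guide.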

Compound 4, half-maximal inhibitory concentration: 0.36 nM
Compound 4: middle estimate off by 3.6-fold (0.56 log units), on the low side; low and high end bracket the measured number.
By their numbers in this assay, from the lowest: compound 3; then compound 4; then compound 1; then compound 2.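

Moving the single fluorine, with the same atoms simply joined differently, gives a 230-fold higher number from compound 3 to compound 4 (2.35 log units; beyond the scatter) in this assay, a large step beyond the scatter. For the compounds shown here, this is the first step that can be read as one change in one place, and it shows that the group on the amide-type nitrogen matters not only as a whole: the place of the fluorine on the phenyl ring alone moves the number a long way, although the counts of atoms, donors and acceptors in the two groups are identical. Nothing available here explains why the 2-fluorophenyl group gives so much lower a number than the 3-fluorophenyl group.

The compounds shown leave open whether the low number of compound 3 at 0.0016 nM depends on fluorine itself, which a 2-chlorophenyl group or a plain phenyl group on the same nitrogen could test. They also leave open how much the rest of the molecule contributes, for example whether a carboxylic acid in place of the ethyl ester would keep this sensitivity to the fluorine's place.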